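Distribution coefficients across a shared core: compound 2 to compound 3

The compounds below may be only part of what the source reports. "The series", "measured", "known", "first", "only" and "open" are said of these compounds alone.

Among the compounds with values here, compound 2 `OC1CN(c2cc(COc3ccc(F)c(F)c3F)nc(-c3ccccn3)n2)C1` stands highest of the two measured members. In a physicochemical assay for lipophilicity, at pH 7.4 (on this read-out lower numbers stand for lower lipophilicity and higher numbers for higher lipophilicity), compound 2 gives 2.8, a gap beyond the usual scatter above its nearest neighbour. Compound 1 `Cc1cc(COc2ccc(S(C)(=O)=O)cc2)nc(-c2ccccn2)n1` gives 1.5 in this assay and so sets the lower end of what has been measured.

Compound 3 `N#CCC1(COc2cc(COc3ccc(F)c(F)c3F)nc(-c3ccccn3)n2)COC1` has not yet been measured. It differs from compound 2 in one place: (3-(cyanomethyl)oxetan-3-yl)methoxy in place of 3-hydroxyazetidin-1-yl on an aromatic carbon. Within the data shown here, no pair of measured compounds carries this change, so the size of its effect in this assay rests on judgement alone. The change removes the one hydrogen-bond donor of the leaving group and enters a larger group with a nitrile, and a modest upward step is expected, estimated as a number 0.40 log units higher from compound 2 to compound 3 (beyond the scatter) in this assay. Compound 3 is therefore expected to give 3.2, with a likely range from 2.6 to 3.8.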

Compound 3, distribution coefficient: 3.3
Compound 3: the middle estimate sits 0.10 log units below what was measured; measured number inside the range.
By their numbers in this assay, from the lowest: compound 1; then compound 2; then compound 3.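

In this assay, within the data shown here, (3-(cyanomethyl)oxetan-3-yl)methoxy in place of 3-hydroxyazetidin-1-yl on this aromatic carbon gives the first single-place comparison, with the read-out landing at a number 0.50 log units higher from compound 2 to compound 3 (beyond the scatter) on the shared core. The read-out therefore responds to a change at this one position, where the entering group carries a nitrile and no hydrogen-bond donor, and the leaving group carries a hydrogen-bond donor and no nitrile. No accompanying measurement bears on the reason for this step.

The compounds shown leave open whether the nitrile, the oxetane ring or the absence of the hydroxyl carries the step. Going by these compounds, how a primary amine or a carboxylic acid on this same aromatic carbon would read in this assay also stays open.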